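Trifluoromethyl to methoxymethyl on an aromatic ring oxygen

This account rests on a few compounds, and the source may have more. Where it says the series, first, only, none or still open, it means among the compounds named here.

In a functional assay on HL-60 cells (Homo sapiens) for cytotoxicity, read by WST assay, with a stated time of 48 h (on this read-out lower numbers stand for an effect already at smaller amounts and higher numbers for an effect only at larger amounts of compound), three compounds sharing one core have been measured. Compound 1 `O=C1OC[C@H](Cc2ccccc2)[C@H]1Cc1ccccc1O` gives 83000 nM, compound 2 `COc1ccccc1C[C@H]1C(=O)OC[C@@H]1Cc1ccccc1` gives 79000 nM, and compound 3 `O=C1OC[C@H](Cc2ccccc2)[C@H]1Cc1ccccc1OC(F)(F)F` gives 39000 nM. Compound 3 thus holds the lowest number of the three, although its distance from each of the other two only modestly exceeds the scatter. The next compound to be tested, compound 4 `COCOc1ccccc1C[C@H]1C(=O)OC[C@@H]1Cc1ccccc1`, carries methoxymethyl in place of trifluoromethyl on an oxygen on an aromatic ring.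

Within the data shown here, three measured steps bear on this change, all at that same oxygen. Methyl in place of hydrogen gives a 1.1-fold lower number from compound 1 to compound 2 (0.02 log units; within the scatter). Trifluoromethyl in place of hydrogen gives a 2.1-fold lower number from compound 1 to compound 3 (0.33 log units; beyond the scatter), and trifluoromethyl in place of methyl gives a 2.0-fold lower number from compound 2 to compound 3 (0.31 log units; beyond the scatter). Among these three compounds, only trifluoromethyl separates one from the others, and no measurement yet exists for methoxymethyl. Compound 2, at 79000 nM, is the nearest measured case, with methyl on that oxygen. The expected result is therefore a modest move to a higher number, a 1.8-fold higher number from compound 3 to compound 4 (0.25 log units; within the scatter). For compound 4 the estimate is 70000 nM, with an expected range from 35000 nM to 140000 nM.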

Compound 4, half-maximal effective concentration: 76000 nM
For compound 4 the middle estimate is 1.1-fold (0.04 log units) below the measured one, within the range that was stated.
By their numbers in this assay, from the lowest: compounds 3, 4, 2 and 1 (each within the scatter of the next, the first and the last beyond it).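

In this assay, among these compounds, the first group with an oxygen of its own at this position, methoxymethyl, barely separates from the smaller substituents, with a 1.1-fold lower number from compound 1 to compound 4 (0.04 log units; within the scatter) and a 1.0-fold lower number from compound 2 to compound 4 (0.02 log units; within the scatter) leaving hydrogen, methyl and methoxymethyl on the oxygen on an aromatic ring indistinguishable. The change from trifluoromethyl gives a 1.9-fold higher number from compound 3 to compound 4 (0.29 log units; within the scatter) and stays within the scatter, so compound 3, although set apart from compound 1 and compound 2 by a modest margin, cannot be told apart from compound 4, and its edge at this position now looks slight rather than clear. The data offer no explanation for any of these numbers.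

On these data alone, what stays open is whether any group on this oxygen can move the number well beyond the scatter, for instance a longer chain such as benzyl, or a chain ending in an amine or a carboxylic acid. Also open, as far as these compounds go, is whether methoxymethyl and trifluoromethyl would stay this close on a core changed elsewhere, since all four compounds share the same remaining structure.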